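Hydrazone aryl variation in a diaryl ether urea series

The source may hold more compounds than are shown below. What is called first, only, known or untested is meant among the compounds shown, and "the series" means these compounds.

Measured compounds:
compound 1 `CN(C)CCn1cnnc1-c1cc(Oc2ccc(NC(=O)N/N=C/c3ccc(F)cc3F)cc2F)ccn1` — 1900 nM
compound 2 `CN(C)CCn1cnnc1-c1cc(Oc2ccc(NC(=O)N/N=C/c3cccc(Cl)c3Cl)cc2F)ccn1` — 13200 nM

Within the data shown here, in a functional assay on U-87MG ATCC cells (Homo sapiens) for cytotoxicity, read by MTT assay, with a stated time of 72 h (a lower number here means a stronger inhibitor, a higher number a weaker inhibitor), compound 2 stands at the higher of the two numbers, with compound 1 as its only neighbour; the gap is a 6.9-fold higher number from compound 1 to compound 2 (0.84 log units; beyond the scatter).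

Compound 3 `CN(C)CCn1cnnc1-c1cc(Oc2ccc(NC(=O)N/N=C/c3cccc(Br)c3)cc2F)ccn1` has not yet been measured in this assay. It differs from compound 2 by 3-bromophenyl in place of 2,3-dichlorophenyl on a carbon with a double bond to nitrogen.

Among the measured compounds shown here, only one measured step bears on this position: a 6.9-fold higher number from compound 1 to compound 2 (0.84 log units; beyond the scatter), a modest shift in which the 2,4-difluorophenyl of compound 1 gave way to the 2,3-dichlorophenyl of compound 2. For the measured compounds named here, that step ran toward a higher number, and the aryl group of compound 3 is a third variant at the same carbon, so no direct precedent exists for it. Going by the values given here, the single step gives a sense of scale but not of direction for this new substituent.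

Given that, compound 3 is expected to land somewhere between the two measured values, nearer compound 2, with the step of a 2.0-fold lower number from compound 2 to compound 3 (0.31 log units; beyond the scatter) estimated as a modest move toward a lower number. The estimate for compound 3 is 6500 nM, with a likely range of 2000 nM to 20000 nM.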

Compound 3, half-maximal inhibitory concentration: 830 nM
Compound 3: the middle estimate sits 7.8-fold (0.89 log units) above what was measured; the whole stated range lies above it.
By their numbers in this assay, from the lowest: compound 3; then compound 1; then compound 2.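

In this assay, the aryl group on a carbon with a double bond to nitrogen proves far more sensitive than the earlier pair alone could show: the change to 3-bromophenyl gives a 16-fold lower number from compound 2 to compound 3 (1.20 log units; beyond the scatter), a larger move than a 6.9-fold higher number from compound 1 to compound 2 (0.84 log units; beyond the scatter). It also takes the series past its earlier low point, with a 2.3-fold lower number from compound 1 to compound 3 (0.36 log units; beyond the scatter), so compound 3 is the strongest of the three, and the 2,4-difluorophenyl and 2,3-dichlorophenyl compounds both stand above it. No measurement at hand accounts for the size of these shifts.

Since the step from 2,3-dichlorophenyl to 3-bromophenyl changes both the halogen and the substitution pattern at once, these compounds leave open how much of the gain belongs to each change. Also unresolved is whether the bromine is needed at all, which unsubstituted phenyl would test, or whether a methoxy group or an amine in its place would hold the lower number in this assay.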